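Fluoro in place of methyl across two cores

The source may hold more compounds than are shown below. What is called first, only, known or untested is meant among the compounds shown, and "the series" means these compounds.

Compound 1 `C/C(=C\c1cc(-c2ccc(C)nc2)co1)C(N)=O` and compound 2 `C/C(=C\c1cc(-c2ccc(F)nc2)co1)C(N)=O` share one core and differ at a single position, while compound 3 `C/C(=C\c1nc(-c2ccc(C)cc2)cs1)C(N)=O` and compound 4 `C/C(=C\c1nc(-c2ccc(F)cc2)cs1)C(N)=O` share another. The difference between the two cores is not broken down here. In a functional assay on BGC-823 cells (Homo sapiens) for cytotoxicity, read by CCK-8 assay, with a stated time of 24 h (a higher number here means a weaker inhibitor, a lower number a stronger inhibitor), compound 1 gives > 50000 nM, which is a limit of the assay rather than a number. In this assay compound 2 gives > 50000 nM, again a limit and not a number. The change between them, (fluoro in place of methyl on an aromatic carbon), thus yields a step that the two limits leave unreadable from compound 1 to compound 2. In this assay compound 3 gives > 50000 nM, once more a limit. All three values sit at the limit of > 50000 nM in this assay, at which 3 of the 3 values shown sit, so no ordering among these compounds can be read.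

Compound 4 has not yet been measured. It differs from compound 3 by fluoro in place of methyl on an aromatic carbon. Among the measured compounds shown here, this is the same kind of change as the one from compound 1 to compound 2, though the place is not identical: in the first pair the change sits on a six-membered aromatic ring with 1 nitrogen, next to the ring nitrogen, whereas in compound 4 it sits on a six-membered aromatic ring of carbon only. The step from compound 3 to compound 4 is expected to be a step that the limit leaves unreadable from compound 3 to compound 4 because compound 3 gives only > 50000 nM. Compound 4 is therefore expected to give 70000 nM in this assay, most likely reported again only as a limit.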

Compound 4, half-maximal inhibitory concentration: > 50000 nM
Compound 4: only a limit was reported; the forecaster's own chance of this, stated with the estimate: 85%; the middle value does not contradict the limit.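

In this assay compound 4 gives > 50000 nM, which is a limit and not a number, so no step can be read between compound 3 and compound 4. All the values shown stand at the same limit: the limit of > 50000 nM in this assay, at which 4 of the 4 values shown sit. The compounds shown leave open whether fluoro in place of methyl, or either core, changes cytotoxicity in this assay at all.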